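Swapping acetyl for dimethylamino on a pyrazole-pyridine scaffold

A few compounds are considered here, and "the series" means these few. Any claim that something is new, unique, unknown or untested is made for them only; others in the source may bear on it.

Of the compounds shown here, two sharing the same core have been tested in a functional assay on A549 cells (Homo sapiens) for inhibition, read by sulforhodamine B assay, with a stated time of 48 h; a higher number here means a weaker inhibitor of growth, a lower number a stronger inhibitor of growth. Compound 1 `COc1cc(C)cc(-c2c(-c3ccnc(-c4ccc(C(C)=O)cc4)c3)cnn2CC#N)c1` gives 3680 nM, the higher of the two numbers. Compound 2 `COc1cc(C)cc(-c2nn(CC#N)cc2-c2ccnc(-c3ccc(N(C)C)cc3)c2)c1`, which also carries a dimethylamino group on its outer phenyl ring, gives 583 nM, a value beyond the scatter from that of compound 1.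

Compound 3 `COc1cc(C)cc(-c2c(-c3ccnc(-c4ccc(N(C)C)cc4)c3)cnn2CC#N)c1` has not yet been measured in this assay. It differs from compound 1 in one place: dimethylamino in place of acetyl on an aromatic carbon, para to a large group.

Because compound 2 with its dimethylamino group gives 583 nM, compound 3 is expected to give a lower number than compound 1, with the step of a 4.1-fold lower number from compound 1 to compound 3 (0.61 log units; beyond the scatter) estimated to lie beyond the scatter. On that basis compound 3 is estimated at 900 nM, with a likely range from 300 nM to 2700 nM.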

Compound 3, concentration for 50% growth inhibition: 155 nM
Compound 3: the middle estimate sits 5.8-fold (0.76 log units) above what was measured; the measured number lies below the stated range.
By their numbers in this assay, from the lowest: compound 3; then compound 2; then compound 1.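

In this assay, among the compounds shown here, the change from 4-acetylphenyl to 4-(dimethylamino)phenyl gives a 24-fold lower number from compound 1 to compound 3 (1.38 log units; beyond the scatter) and thus provides the first direct reading of a single change at this position, para to a large group. The step is large even though the two groups have the same number of heavy atoms and hydrogen-bond acceptors; the change is that carbon and oxygen give way to carbon and nitrogen, and the double bond outside aromatic rings is lost. Nothing available here bears on the cause of this step.

From the compounds shown here alone, it remains open whether the lower number is particular to dimethylamino or would also be seen with a primary amine, a morpholine or a methoxy group at this position. A counterpart of compound 2 carrying acetyl would show whether the step also holds in that arrangement of the core.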